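Hydroxymethyl for formyl on a phenylethynyl phenylpropanoic acid

The source may report more compounds than this note shows. Statements on the series, on what has been measured and on what is new or still open speak of the compounds shown alone.

In an in vitro functional assay on 1321-N1 cells for agonist activity at Free fatty acid receptor 1 (Homo sapiens), read by fluorescence (on this read-out lower numbers stand for an effect already at smaller amounts and higher numbers for an effect only at larger amounts of compound), compound 1 `O=C(O)CCc1ccc(C#Cc2ccccc2)cc1` gives 95.5 nM; 96 nM (2 entries), and its repeated entries the several entries of compound 1 in this assay, 95.5 nM; 96 nM (2 entries) agree closely. Compound 3 `Cc1cc(C)cc(C#Cc2ccc(CCC(=O)O)cc2)c1` gives 74.1 nM, while compound 2 `O=Cc1cccc(C#Cc2ccc(CCC(=O)O)cc2)c1` gives 355 nM, the highest number among the compounds with a single figure here and beyond the scatter above compound 3. Compound 4 `O=C(O)CCc1ccc(C#Cc2cccc(CO)c2)cc1` differs from compound 2 by hydroxymethyl in place of formyl on an aromatic carbon. Within the data shown here, no measured pair shows this change, so the expectation rests on compounds 1 and 3, which carry other groups on the same core and sit lower. Compound 4 is therefore expected to give a somewhat lower number than compound 2 in this assay, a step of a 2.2-fold lower number from compound 2 to compound 4 (0.35 log units; beyond the scatter), estimated at 160 nM within a range from 50 nM to 500 nM.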

Compound 4, half-maximal effective concentration: 891 nM
Compound 4: the middle estimate sits 5.6-fold (0.75 log units) below what was measured; measured number outside the range, above it.
By their numbers in this assay, from the lowest: compound 3; then compound 2; then compound 4.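

In this assay, hydroxymethyl in place of formyl on an aromatic carbon, meta to a large group, gives a 2.5-fold higher number from compound 2 to compound 4 (0.40 log units; beyond the scatter). Among these compounds, this is the first direct reading of a change at this position, and it shows that the swap, which brings in a hydrogen-bond donor that formyl lacks, goes to a higher number rather than a lower one. No measurement shown here bears on what lies behind this step.

The compounds shown leave open how an amine or a methoxy group at this position would compare with formyl and hydroxymethyl. They also leave open whether hydroxymethyl would give a similar step elsewhere on the same ring.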